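Swapping methoxy for chloro on the aryl ketone ring

A few compounds are considered here, and "the series" means these few. Any claim that something is new, unique, unknown or untested is made for them only; others in the source may bear on it.

Compound 1 `COc1cc(-c2cc(/C=C/C(=O)c3ccccc3)[nH]n2)cc(OC)c1OC` gives 2300 nM in a functional assay on MDA-MB-231 cells (Homo sapiens) for inhibition, read by MTT assay, with a stated time of 48 h; on this read-out higher numbers stand for weaker inhibition and lower numbers for stronger inhibition; compound 2 `COc1ccc(C(=O)/C=C/c2cc(-c3cc(OC)c(OC)c(OC)c3)n[nH]2)cc1` gives 950 nM.

Of the two numbers shown, compound 2 stands at the lower end: a 2.4-fold lower number from compound 1 to compound 2 (0.38 log units; beyond the scatter). Compound 3 `COc1cc(-c2cc(/C=C/C(=O)c3ccc(Cl)cc3)[nH]n2)cc(OC)c1OC` is not yet measured. It differs from compound 2 in one place, (chloro in place of methoxy on an aromatic carbon), the site being on an aromatic carbon of a six-membered aromatic ring of carbon only, para to a large group.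

Going by the values given here, only one measured step exists, that from compound 1 to compound 2, and it concerns a hydrogen giving way to methoxy at this same position. Among the compounds with values here, it says nothing directly about chloro, since no measured pair replaces methoxy with chloro. The step is modest, so the whole spread of the known data is narrow, and a chloro group at the same site is expected to land somewhere inside or near that spread. The expectation is therefore a step of a 1.4-fold higher number from compound 2 to compound 3 (0.14 log units; within the scatter), which should stay within the scatter. Compound 3 is estimated at 1300 nM, with a range from 500 nM to 3200 nM.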

Compound 3, half-maximal inhibitory concentration: 26000 nM
The estimate for compound 3 lay 20-fold (1.30 log units) below the measured number; the measured number lies above the stated range.
By their numbers in this assay, from the lowest: compound 2; then compound 1; then compound 3.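

Going by these compounds alone, the single earlier step, a modest one (a 2.4-fold lower number from compound 1 to compound 2 (0.38 log units; beyond the scatter)), gave little sign of how much this position matters in this assay: replacing 4-methoxyphenyl with 4-chlorophenyl produces a far larger change (a 27-fold higher number from compound 2 to compound 3 (1.44 log units; beyond the scatter)). Chloro also compares poorly with plain hydrogen at the same site (an 11-fold higher number from compound 1 to compound 3 (1.05 log units; beyond the scatter)), so the two substituents move the number in opposite directions from compound 1, with methoxy lowering it and chloro raising it. The outcome at this aromatic carbon therefore depends strongly on which group sits there, not merely on whether the hydrogen has been replaced, and nothing available here accounts for why methoxy and chloro part so sharply.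

With only hydrogen, methoxy and chloro shown at this site, three points cannot establish a trend, and it remains open whether an amine, a hydroxyl, a fluoro or an ethoxy group would track methoxy, track chloro or fall elsewhere. On these data alone, it is also open whether the same order of the three groups would hold in a different cell line or with a change elsewhere on the shared core.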